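Aryl ring substitution in the cyclopentylamine tetralin series

The source may hold more compounds than are shown below. What is called first, only, known or untested is meant among the compounds shown, and "the series" means these compounds.

Measured compounds:
compound 1 `N[C@]1(CO)CC[C@H](c2ccc3c(c2)CC[C@@H](COc2ccc(F)cc2)C3)C1`: 74%
compound 2 `COc1ccc(OC[C@@H]2CCc3cc([C@H]4CC[C@](N)(CO)C4)ccc3C2)cc1`: 47%

Two compounds have been run in a functional assay on the whole organism (strain Lewis) with Rattus norvegicus as the target, with a stated time of 24 h, at a dose of 2 mg/kg by the oral route; a lower number here means less inhibition, a higher number more inhibition at the dose given (going by the name of the read-out). Compound 1 gives 74% in this assay, while compound 2 gives 47%, the lowest of the two numbers; the step of a number 27 percentage points lower from compound 1 to compound 2 (beyond the scatter) corresponds to methoxy in place of fluoro on an aromatic carbon.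

The next compound is compound 3 `COc1ccc(OC[C@@H]2CCc3cc([C@H]4CC[C@](N)(CO)C4)ccc3C2)c(F)c1F`, not yet measured in this assay. It differs from compound 2 by 2,3-difluoro-4-methoxyphenyl in place of 4-methoxyphenyl on an oxygen on a saturated carbon. Going by the values given here, no measured step carries fluorine onto a ring that already bears methoxy, so the only step that bears on it is the one from compound 1 to compound 2, where fluoro went with the higher number and methoxy with the lower. Compound 3 keeps the methoxy and adds two fluorines, so a rise toward the number of compound 1 seems plausible but is not secured by a direct precedent. For compound 3 the expected step is a number 11 percentage points higher from compound 2 to compound 3 (beyond the scatter), modest in size. The estimate for compound 3 in this assay is 58%, with a range from 40% to 76%.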

Compound 3, a percentage reported as inhibition, in the whole organism at one dose (the size of the read-out at that dose, not a potency): 48%
Estimate against measurement, compound 3: 10 percentage points above, within the range that was stated.
By their numbers in this assay, from the lowest: compounds 2 and 3 (each within the scatter of the next); then compound 1.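

With 2,3-difluoro-4-methoxyphenyl in place of 4-methoxyphenyl on the oxygen, this assay gives a number 1 percentage points higher from compound 2 to compound 3 (within the scatter), so the two fluorines make no difference that can be read at this dose when the methoxy group stays on the ring. The gap to the 4-fluorophenyl group remains, with a number 26 percentage points lower from compound 1 to compound 3 (beyond the scatter), and the two methoxy-bearing compounds now sit together, apart from compound 1; fluorine on the ring does not by itself go with the higher number, as compound 3 carries two fluorines and still lies within the scatter of compound 2. No data on hand point to what lies behind either step.

Open, on these data alone, is whether methoxy alone sets the lower number, which a 2,3-difluorophenyl group without methoxy would test, and how a chloro or trifluoromethyl group would read in place of methoxy on the same ring. All three numbers also come from a single oral dose and a single time in this assay, so they show the size of the read-out there and leave the ranking at other doses or times unsettled.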